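A larger group on the aromatic ring

The compounds below may be only part of what the source reports. "The series", "measured", "known", "first", "only" and "open" are said of these compounds alone.

Compound 1 `Cc1ccc(CC(C)(Oc2ccc(C(C)C)cc2)C(=O)O)cc1` has no exact number in a functional assay on the whole organism for inhibition, with Rattus norvegicus as the target; a lower number here means that less compound is needed, a higher number that more compound is needed for the effect. Compound 1 reads < 1 mg/kg, which is a limit of the assay. Compound 2 `CCc1cccc(CC(C)(Oc2ccc(C(C)C)cc2)C(=O)O)c1` gives 0.5 mg/kg. Within the data shown here, the only measured step is a step that the limit leaves unreadable from compound 1 to compound 2, so it offers no size to carry over. Compound 3 `CC(C)c1ccc(OC(C)(Cc2ccc(C(C)(C)C)cc2)C(=O)O)cc1` has tert-butyl in place of methyl on an aromatic carbon, para to a large group (tert-butyl in place of methyl on an aromatic carbon). Among the measured compounds shown here, no measured step covers this change, so the expectation rests on compound 2 at 0.5 mg/kg, with no clear direction. The expected step is a step that the limit leaves unreadable from compound 1 to compound 3. In this assay the estimate for compound 3 is 0.7 mg/kg, with an expected range from 0.2 mg/kg to 3 mg/kg.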

Compound 3, dose for half-maximal effect: 5 mg/kg
For compound 3 the middle estimate is 7.1-fold (0.85 log units) below the measured one; the whole stated range lies below it.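

In this assay, tert-butyl in place of methyl on this aromatic carbon gives an at least 5.0-fold higher number from compound 1 to compound 3 (0.69 log units; beyond the scatter), so here the larger group goes with a need for more compound. Among these compounds, the earlier step cannot be read, which makes this the first step with a readable size. That size rests on compound 1, whose value is a limit: the limit of < 1 mg/kg in this assay, at which 1 of the 3 values shown sits.

Still open, going by these compounds, is whether a methoxy group or a chlorine atom on this same carbon would read closer to compound 1 or to compound 3.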